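The source may hold more compounds than are shown below. What is called first, only, known or untested is meant among the compounds shown, and "the series" means these compounds.

Measured so far:
compound 1, `COc1ccc(Oc2ccc([N+](=O)[O-])cc2-c2ccsc2S(=O)(=O)N2CCN(C(=O)Nc3ccc([N+](=O)[O-])cc3)CC2)cc1OC`: 19%
compound 2, `O=C(Nc1ccc(F)cc1)N1CCN(S(=O)(=O)c2sccc2-c2ccccc2Oc2ccc(O)c(O)c2)CC1`: 33%

Both numbers come from an assay for binding affinity to Apoptosis regulator Bcl-2 (Homo sapiens), read by fluorescence polarization, with stated times of 30 min and 20 min, tested at 100 uM; on this read-out lower numbers stand for less inhibition and higher numbers for more inhibition at the one concentration tested (going by the name of the read-out). Compound 2 stands highest of the two numbers; its nearest neighbour, compound 1, gives 19%, a gap beyond the usual scatter. Among the compounds with values here, the two compounds differ in several places at once, so no single change can be read from their values; they show only that compound 2 sits above compound 1.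

The next compound, compound 3, `O=C(Nc1ccc([N+](=O)[O-])cc1)N1CCN(S(=O)(=O)c2sccc2-c2ccccc2Oc2ccc(O)c(O)c2)CC1`, differs from compound 2 in one place: nitro in place of fluoro on an aromatic carbon. Within the data shown here, no measured pair shows this change on its own, so there is no measured step to lean on. Compound 1 also carries the (4-nitrophenyl)carbamoyl group and gives the lower of the two numbers, but it differs from compound 2 elsewhere as well, so that comparison carries little weight. The expected step is small, a number 5 percentage points lower from compound 2 to compound 3 (within the scatter), leaning slightly downward but within the usual scatter. In this assay compound 3 is therefore estimated at 28%, with a range from 12% to 45%.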

Compound 3, a percentage reported as inhibition, at one concentration (the size of the read-out at that concentration, not a potency): 33%
The estimate for compound 3 lay 5 percentage points below the measured number; the measured number falls inside the stated range.
By their numbers in this assay, from the lowest: compound 1; then compounds 2 and 3 (each within the scatter of the next).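

In this assay, within the data shown here, the exchange of fluoro for nitro on an aromatic carbon, para to a large group, gives no change at the digits printed from compound 2 to compound 3 (within the scatter), and this is the first step that isolates a single change. With the rest of compound 2 held constant, this position accepts the move from 4-fluorophenyl to 4-nitrophenyl with no difference that the read-out can resolve, even though the entering group brings three heavy atoms and two hydrogen-bond acceptors where the leaving group has one heavy atom and no acceptor. No accompanying measurement bears on why the two groups read alike.

The compounds shown leave open whether an amine or a carboxylic acid on this same aromatic carbon would move the number beyond the scatter, as fluoro and nitro alone give only a narrow view of the position. Among these compounds, they also leave open whether the same exchange would read alike on another core, such as that of compound 1, as the single step comes from one pair at one concentration.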